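Methoxy Added to a Nitro-Bearing Compound Without Measurable Cytotoxicity

The compounds below may be only part of what the source reports. "The series", "measured", "known", "first", "only" and "open" are said of these compounds alone.

Compound 1 `COc1ccc2[nH]c(=O)c(-c3nc4cc(F)ccc4[nH]3)cc2c1`: in a functional assay on SK-OV-3 cells (Homo sapiens) for cytotoxicity, read by MTT assay, with a stated time of 48 h (a higher number here means a weaker inhibitor, a lower number a stronger inhibitor), compound 1 gives > 100000 nM, a limit of the assay.
Compound 2 `O=c1[nH]c2ccccc2cc1-c1nc2cc([N+](=O)[O-])ccc2[nH]1`: in this assay compound 2 gives > 100000 nM, again a limit.

Among the compounds with values here, compound 2 thus stands at the limit of this assay rather than at a measured number, and the only other value shown is also a limit, so that the limit of > 100000 nM in this assay, at which 2 of the 2 values shown sit, summarises everything known here. Compound 3 `COc1ccc2[nH]c(=O)c(-c3nc4cc([N+](=O)[O-])ccc4[nH]3)cc2c1` differs from compound 2 by methoxy in place of hydrogen on an aromatic carbon. Within the data shown here, no step between measured compounds is available, so no direction can be read from the data. Compound 3 is expected to remain at the limit, a step of none beyond the scatter, which is what a number no higher from compound 2 to compound 3 (the limit leaves the size open) means. Compound 3 is therefore estimated at 100000 nM in this assay, with a range from 30000 nM to 300000 nM.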

Compound 3, half-maximal inhibitory concentration: > 100000 nM
Compound 3 was reported as a limit; the forecaster's own chance of this, stated with the estimate: 85%; the middle value sits exactly at the limit.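

No step can be read from compound 2 to compound 3 or from compound 1 to compound 3, because all three compounds stand at the same limit: the limit of > 100000 nM in this assay, at which 3 of the 3 values shown sit. The compounds shown leave open whether methoxy in place of hydrogen, or nitro in place of fluoro, changes the result in this assay at all.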